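Swapping the aryl ring for thiophene on a shared core

The compounds below may be only part of what the source reports. "The series", "measured", "known", "first", "only" and "open" are said of these compounds alone.

Compound 3 `COc1ccc(-c2cc(-c3nc4ccccc4n3C)nc(OC)c2C#N)cc1` gives 210000 nM in a functional assay on aorta (Rattus norvegicus, strain Wister); a lower number here means a stronger inhibitor, a higher number a weaker inhibitor.
Compound 2 `COc1nc(-c2nc3ccccc3n2C)cc(-c2ccc(C)cc2)c1C#N` gives 295000 nM in this assay.
Compound 1 `COc1nc(-c2nc3ccccc3n2C)cc(-c2ccc(F)cc2)c1C#N` gives 343000 nM in this assay.

Compound 3 sits at the low end of these three numbers, but the distance to the others is small: a 1.4-fold lower number from compound 2 to compound 3 (0.15 log units; within the scatter) and a 1.6-fold lower number from compound 1 to compound 3 (0.21 log units; within the scatter), both within the scatter. The three compounds differ only in the group on one aromatic ring, and a 1.2-fold lower number from compound 1 to compound 2 (0.07 log units; within the scatter) shows that this exchange also changed nothing beyond the scatter.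

Compound 4 `COc1nc(-c2nc3ccccc3n2C)cc(-c2cccs2)c1C#N` has not yet been measured. It differs from compound 3 by thiophen-2-yl in place of 4-methoxyphenyl on an aromatic carbon. This exchange is larger than the earlier ones, since a whole six-membered ring gives way to a five-membered one with a sulfur atom, so the measured steps bear on it only loosely. What they do show is that three different groups at this position gave numbers that all lie within the scatter of one another. On that basis compound 4 is expected to give about 260000 nM in this assay, with a range from 100000 nM to 700000 nM; this estimate means a 1.2-fold higher number from compound 3 to compound 4 (0.09 log units; within the scatter), a step that is expected to stay within the scatter.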

Compound 4, half-maximal inhibitory concentration: 312000 nM
Compound 4: middle estimate off by 1.2-fold (0.08 log units), on the low side, and the stated range covers the measured number.
By their numbers in this assay, from the lowest: compounds 3, 2, 4 and 1 (each within the scatter of the next).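

Until now only the small group carried on a six-membered aromatic ring of carbon had varied, but here the ring itself gives way to thiophen-2-yl, with fewer heavy atoms and a sulfur atom, and this assay still shows no change beyond the scatter, with a 1.5-fold higher number from compound 3 to compound 4 (0.17 log units; within the scatter). The same holds when the thiophene is set against the other two aromatic rings, with a 1.1-fold higher number from compound 2 to compound 4 (0.02 log units; within the scatter) and a 1.1-fold lower number from compound 1 to compound 4 (0.04 log units; within the scatter). So among these four compounds, neither the group on the ring nor the size of the ring at this position, opposite the ring nitrogen, separates the numbers.

No measurement shown offers a reason for this flat result. Still open, on these data alone, is whether a group of a different kind here, such as an amine, a carboxylic acid or a longer alkyl chain, would move the number beyond the scatter, and whether a change elsewhere on the shared core would do so.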